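Adding a Methyl to the Chain of Compound 3

The compounds below may be only part of what the source reports. "The series", "measured", "known", "first", "only" and "open" are said of these compounds alone.

In a functional assay on A549 cells (Homo sapiens) for inhibition, read by MTT assay, with a stated time of 72 h (a lower number here means a stronger inhibitor, a higher number a weaker inhibitor), the compounds measured so far are:
compound 1 `CC/C=C/C(=O)Nc1cccc(Oc2nc(Nc3cccc(OC)c3)nc3ccsc23)c1`, giving 19600 nM;
compound 2 `COc1cccc(Nc2nc(Oc3cccc(NC(=O)/C=C/C(C)C)c3)c3sccc3n2)c1`, giving 37100 nM;
compound 3 `CC/C=C/C(=O)Nc1cccc(Oc2nc(Nc3cccc(C#N)c3)nc3ccsc23)c1`, giving 14900 nM.

Compound 2 differs from compound 1 by methyl in place of hydrogen on a saturated chain carbon bound to a double-bonded chain carbon and a saturated chain carbon; that change gave a 1.9-fold higher number from compound 1 to compound 2 (0.28 log units; within the scatter). Compound 3 differs from compound 1 by cyano in place of methoxy on an aromatic carbon, giving a 1.3-fold lower number from compound 1 to compound 3 (0.12 log units; within the scatter). Compound 4 `CC(C)/C=C/C(=O)Nc1cccc(Oc2nc(Nc3cccc(C#N)c3)nc3ccsc23)c1` is not yet measured; it differs from compound 3 by methyl in place of hydrogen on a saturated chain carbon bound to a double-bonded chain carbon and a saturated chain carbon, the same change, at the same place, as between compound 1 and compound 2. Since the earlier step was a 1.9-fold higher number from compound 1 to compound 2 (0.28 log units; within the scatter), a step of like size is expected from compound 3 to compound 4 in this assay, namely a 1.8-fold higher number from compound 3 to compound 4 (0.26 log units; within the scatter), resting on that single prior example. Compound 4 is estimated at 27000 nM, between 10000 nM and 70000 nM.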

Compound 4, half-maximal inhibitory concentration: 19000 nM
For compound 4 the middle estimate is 1.4-fold (0.15 log units) above the measured one; the measured number falls inside the stated range.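

In this assay the methyl in place of hydrogen on the chain gave a 1.3-fold higher number from compound 3 to compound 4 (0.11 log units; within the scatter) and matched its earlier step: the same change on two cores in this assay, a 1.9-fold higher number (0.28 log units; within the scatter) from compound 1 to compound 2 and a 1.3-fold higher number (0.11 log units; within the scatter) from compound 3 to compound 4, 1.5-fold (0.17 log units) apart, within the scatter of two such steps. Cyano in place of methoxy gave a 2.0-fold lower number from compound 2 to compound 4 (0.29 log units; within the scatter) and likewise matched its earlier step: the same change on two cores in this assay, a 1.3-fold lower number (0.12 log units; within the scatter) from compound 1 to compound 3 and a 2.0-fold lower number (0.29 log units; within the scatter) from compound 2 to compound 4, 1.5-fold (0.17 log units) apart, within the scatter of two such steps. Within the data shown here, each change therefore carried from one core to the other without a detectable difference, but this rests on only two pairs per change, and with every step within the scatter, it does not show that either change has any real effect on the number here.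

The compounds shown leave open how a longer chain would behave in place of the isopropyl. They also leave open how an amine would behave in place of the nitrile.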